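Lactone amides with phenyl-terminated chains: ring shift

The source may report more compounds than this note shows. Statements on the series, on what has been measured and on what is new or still open speak of the compounds shown alone.

Compound 1 `O=C(CCCCCCCCCCCc1ccccc1)CC(=O)N[C@H]1CCOC1=O`: 4000 nM
Compound 2 `O=C(CCCCCCCCCCc1ccccc1)N[C@H]1CCOC1=O`: 66000 nM
Compound 3 `O=C(CCCCCCCCCCc1ccccc1)CC(=O)N[C@H]1CCOC1=O`: 2000 nM

All three were run in a functional assay on PC-3 cells (Homo sapiens) for cytotoxicity, read by sulforhodamine B assay, with a stated time of 5 days; on this read-out lower numbers stand for stronger inhibition and higher numbers for weaker inhibition. Compound 1 and compound 3 share one core; compound 2 has a different core, and the difference between the two cores is not broken down here. Between compound 3 and compound 1 the change is benzyl in place of phenyl on a saturated chain carbon, ten or more bonds along the chain from a carbonyl carbon, and it gives a 2.0-fold higher number from compound 3 to compound 1 (0.30 log units; within the scatter). Compound 2 gives the highest of the three numbers, and its gap to compound 1 and to compound 3 is beyond the scatter.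

Compound 4 `O=C(CCCCCCCCCCCc1ccccc1)N[C@H]1CCOC1=O` is not yet measured. It differs from compound 2 by benzyl in place of phenyl on a saturated chain carbon, ten or more bonds along the chain from a carbonyl carbon, the same change as that from compound 3 to compound 1. Because a 2.0-fold higher number from compound 3 to compound 1 (0.30 log units; within the scatter) was within the scatter, the expectation is a step of similar size in this assay: a 1.5-fold higher number from compound 2 to compound 4 (0.18 log units; within the scatter), resting on that one pair only. Compound 4 is thus expected to give 100000 nM, with a likely range from 40000 nM to 250000 nM.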

Compound 4, half-maximal inhibitory concentration: > 100000 nM
Compound 4 ended at the assay's limit; the forecaster's own chance of this, stated with the estimate: 20%; the middle value sits exactly at the limit.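

In this assay compound 4 gives > 100000 nM, which is a limit of the assay and not a number. Benzyl in place of phenyl on the core of compound 2 therefore reads only as a floor, an at least 1.5-fold higher number from compound 2 to compound 4 (0.18 log units; that floor lies within the scatter), and set beside the same change on the other core the comparison reads: the same change on two cores in this assay, a 2.0-fold higher number (0.30 log units; within the scatter) from compound 3 to compound 1 and an at least 1.5-fold higher number (0.18 log units; that floor lies within the scatter) from compound 2 to compound 4; the limit leaves it open whether they differ Neither core contradicts the carry-over of this change, but equal step sizes on the two cores are not shown, as the step on the core of compound 2 has a floor and no upper end.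

The compounds shown leave open how the two cores respond to a shorter chain or a longer chain, since the change is read at only one chain pair on each core. Also open, as far as these compounds go, is whether a fluorine or a hydroxyl on the phenyl ring, or a carboxylic acid in its place, would shift the numbers on either core.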